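Swapping Methoxy for Fluoro on a Shared Core

The source may hold more compounds than are shown below. What is called first, only, known or untested is meant among the compounds shown, and "the series" means these compounds.

Compound 1 `COc1ccc(-n2sc(=O)n(-c3ccccc3)c2=O)cc1` has been tested in an ADME assay, in phosphate buffer, with a stated time of 30 min, tested at 1 mM, at a dose of 1 mM; on this read-out higher numbers stand for higher exposure at the dose given and lower numbers for lower exposure. In this assay compound 1 gives < 2000 nM, which is a limit of the assay rather than a number. Compound 2 `COc1ccc(-n2sc(=O)n(C3CCCCC3)c2=O)cc1` gives < 2000 nM, also a limit. Compound 3 `COc1ccc(-n2sc(=O)n(-c3ccc(Cl)cc3)c2=O)cc1` gives < 2000 nM, again a limit. All three values sit at the limit of < 2000 nM in this assay, at which 3 of the 3 values shown sit. As a result the steps a step that the two limits leave unreadable from compound 1 to compound 2, a step that the two limits leave unreadable from compound 1 to compound 3 and a step that the two limits leave unreadable from compound 2 to compound 3 cannot be read in size or direction, and compound 1 stands at a limit with no readable neighbour.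

Compound 4 `O=c1sn(-c2ccc(F)cc2)c(=O)n1-c1ccccc1` differs from compound 1 by fluoro in place of methoxy on an aromatic carbon. For the measured compounds named here, none of the measured steps touches this position, and none has a readable size, so they offer no guidance on how large a step to expect in this assay. Going by the values given here, what the measurements do show is that every compound so far sits at the limit. The step from compound 1 to compound 4 is therefore expected to be small: a step that the limit leaves unreadable from compound 1 to compound 4. Compound 4 is expected to give 1000 nM, in a range from 300 nM to 3000 nM, and most likely to be reported again as a limit.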

Compound 4, maximal plasma concentration: < 2000 nM
Compound 4 was reported as a limit (the forecaster's own chance of this, stated with the estimate: 75%); the middle value lies beyond the limit too.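

Compound 4 and compound 1 are both reported only as limits, so the step from methoxy to fluoro cannot be read in size or direction: the limit of < 2000 nM in this assay, at which 4 of the 4 values shown sit. The compounds shown leave open where any of the four truly stands, and whether either change of group alters maximal plasma concentration at all.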